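From compound 3 to compound 4: adding methoxy

The source may report more compounds than this note shows. Statements on the series, on what has been measured and on what is new or still open speak of the compounds shown alone.

Measured in a functional assay on HL-60 cells (Homo sapiens) for antiproliferative activity, read by CellTiter-Glo, with a stated time of 72 h; a higher number here means a weaker inhibitor, a lower number a stronger inhibitor:
- compound 1 `CO[C@@H]1[C@H](N(C)c2ncc(-c3c[nH]c4ccc(F)cc34)s2)C[C@H]2O[C@]1(C)n1c3ccccc3c3c4c(c5c6ccccc6n2c5c31)C(=O)NC4`: > 10000 nM (a limit)
- compound 2 `CO[C@@H]1[C@H](N(C)c2ncc(-c3c[nH]c4ccc(Br)cc34)s2)C[C@H]2O[C@]1(C)n1c3ccccc3c3c4c(c5c6ccccc6n2c5c31)C(=O)NC4`: > 10000 nM (a limit)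
- compound 3 `CO[C@@H]1[C@H](N(C)c2ncc(-c3c[nH]c4ccccc34)s2)C[C@H]2O[C@]1(C)n1c3ccccc3c3c4c(c5c6cc(Cl)ccc6n2c5c31)C(=O)NC4`: > 10000 nM (a limit)

Among the measured compounds shown here, no measured compound has yet given a number, and the series stands at the limit of > 10000 nM in this assay, at which 3 of the 3 values shown sit. Compound 3 therefore offers only a limit as a starting point, with no exact value against which to set a change.

Compound 4 `COc1ccc2[nH]cc(-c3cnc(N(C)[C@@H]4C[C@H]5O[C@@](C)([C@@H]4OC)n4c6ccccc6c6c7c(c8c9cc(Cl)ccc9n5c8c64)C(=O)NC7)s3)c2c1` carries methoxy in place of hydrogen on an aromatic carbon, taking 1H-indol-3-yl to 5-methoxy-1H-indol-3-yl: methoxy in place of hydrogen on an aromatic carbon.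

For the measured compounds named here, the only measured step that bears on this change is a step that the two limits leave unreadable from compound 1 to compound 2, which also alters a group on an aromatic carbon. It supplies no size to carry over, so no particular size or direction of step is expected in this assay. The most likely result is another limit.

The estimated step is a step that the limit leaves unreadable from compound 3 to compound 4. For compound 4 the expected value is 12000 nM, with an estimated range from 5000 nM to 30000 nM.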

Compound 4, half-maximal inhibitory concentration: > 10000 nM
Compound 4: no number, only a limit; the forecaster's own chance of this, stated with the estimate: 85%; the middle value lies beyond the limit too.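

Compound 4 gives > 10000 nM in this assay, which is a limit and not a number, so no step can be read from compound 3 to compound 4. The compounds shown leave open whether any change on the shared core would give a measurable value, as every result so far is a limit: the limit of > 10000 nM in this assay, at which 4 of the 4 values shown sit.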